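Hydroxy to ethoxy on compound 2: working notes

The source may report more compounds than this note shows. Statements on the series, on what has been measured and on what is new or still open speak of the compounds shown alone.

Measured in an ADME assay on HEK293 cells (Homo sapiens) for cytotoxicity, read by MTT assay, with a stated time of 48 h; a lower number here means a stronger inhibitor, a higher number a weaker inhibitor:
- compound 1 `O=C1/C(=C\c2ccc([N+](=O)[O-])cc2)S/C(=N/c2ccccc2)N1Cc1ccncc1`: 250000 nM
- compound 2 `O=C1/C(=C\c2ccc(O)c(O)c2)S/C(=N/c2ccccc2)N1Cc1ccncc1`: 230000 nM

Compound 2 stands within the scatter of compound 1, as shown by a 1.1-fold lower number from compound 1 to compound 2 (0.04 log units; within the scatter). Next comes compound 3 `CCOc1cc(/C=C2/S/C(=N/c3ccccc3)N(Cc3ccncc3)C2=O)ccc1O`, with ethyl in place of hydrogen on an oxygen on an aromatic ring, that is, hydroxy to ethoxy, giving 3-ethoxy-4-hydroxyphenyl. For the measured compounds named here, no measured step covers this exact change. The only one bearing on it, a 1.1-fold lower number from compound 1 to compound 2 (0.04 log units; within the scatter), replaces 4-nitrophenyl with 3,4-dihydroxyphenyl. In this assay, the expected 1.0-fold lower number from compound 2 to compound 3 (0.02 log units; within the scatter) therefore stays within the scatter, with no direction favoured. For compound 3, the estimated value is 220000 nM, with an expected range of 110000 nM to 400000 nM.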

Compound 3, half-maximal inhibitory concentration: 46500 nM
Compound 3: middle estimate off by 4.7-fold (0.67 log units), on the high side; measured number below the stated range.
By their numbers in this assay, from the lowest: compound 3; then compounds 2 and 1 (each within the scatter of the next).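

In this assay, for the compounds shown here, ethyl on the oxygen on the aromatic ring gives a 4.9-fold lower number from compound 2 to compound 3 (0.69 log units; beyond the scatter) and so shows that this position responds to the hydroxy to ethoxy change, which the earlier compounds could not show. Against 4-nitrophenyl, 3-ethoxy-4-hydroxyphenyl gives a 5.4-fold lower number from compound 1 to compound 3 (0.73 log units; beyond the scatter) while 3,4-dihydroxyphenyl stayed within the scatter of it. Nothing available explains this shift.

Open, going by these compounds, is whether methyl or a longer chain on this oxygen gives a step of similar size. Also open, on these data alone, is what an amine or a carboxylic acid would do in place of ethoxy.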